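Replacing 4-nitrophenyl with 2,4-dichlorophenyl: an open question

A few compounds are considered here, and "the series" means these few. Any claim that something is new, unique, unknown or untested is made for them only; others in the source may bear on it.

Measured compounds in a functional assay on MCF7 cells (Homo sapiens) for cytotoxicity, read by MTT assay, with a stated time of 72 h; on this read-out lower numbers stand for stronger inhibition and higher numbers for weaker inhibition:
- compound 1 `CNC(=O)c1cc(Oc2ccc(C(=O)/C=C/c3ccc([N+](=O)[O-])cc3)cc2)ccn1` gives ("not determined" (no result reported))
- compound 2 `CNC(=O)c1cc(Oc2ccc(/C=C/C(=O)c3ccc(Br)cc3)cc2)ccn1` gives (7100 nM)

The starting point of this account offers no number. In this assay, on these data alone, compound 1 has the entry ("not determined" (no result reported)), so its standing on this read-out is unknown and it cannot be ranked against compound 2.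

The next compound to be tested is compound 3 `CNC(=O)c1cc(Oc2ccc(C(=O)/C=C/c3ccc(Cl)cc3Cl)cc2)ccn1`. It keeps the core of compound 1 and carries 2,4-dichlorophenyl in place of 4-nitrophenyl on a double-bonded chain carbon bound to a double-bonded chain carbon.

Among the compounds with values here, no measured pair in this small set shows what a change in this place does. With no value at compound 1, a step from it cannot be sized, and no direction is expected. Within the data shown here, the only numerical anchor is compound 2 (7100 nM), which differs from compound 3 in more than one place. The expectation therefore stays near that value, with a wide margin on both sides.

The estimated value for compound 3 is 6500 nM (expected range 1500 nM to 28000 nM).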

Compound 3, half-maximal inhibitory concentration: 3990 nM
Beside the measured number, compound 3's estimate is 1.6-fold (0.21 log units) above it; the range from low to high includes it.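

In this assay, within the data shown here, compound 1 gives "not determined" (no result reported), so no step from it to compound 3, at 3990 nM, can be read. On these data alone, what replacing 4-nitrophenyl with 2,4-dichlorophenyl does to cytotoxicity on the shared core therefore stays open. Nothing shown here offers an explanation for the value of compound 3.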